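Swapping the aryl group of compound 2 for a methylfuran

This account rests on a few compounds, and the source may have more. Where it says the series, first, only, none or still open, it means among the compounds named here.

Compound 1 `N#CC1=C(N)N(c2ccc(S(N)(=O)=O)cc2)C2=C(C(=O)CCC2)C1c1ccccc1`: 40%
Compound 2 `N#CC1=C(N)N(c2ccc(S(N)(=O)=O)cc2)C2=C(C(=O)CCC2)C1c1cccc([N+](=O)[O-])c1`: 71%

Compound 2 gives the higher of the two numbers in a functional assay on Ehrlich cells (Mus musculus) for antiproliferative activity, read by trypan blue exclusion, with a stated time of 2 h, tested at 100 ug/mL; a higher number here means a stronger effect of the compound at the concentration tested, a lower number a weaker effect; compound 1 sits well below it. The step to compound 3 `Cc1ccoc1C1C(C#N)=C(N)N(c2ccc(S(N)(=O)=O)cc2)C2=C1C(=O)CCC2` is 3-methylfuran-2-yl in place of 3-nitrophenyl on a saturated ring carbon. Among the compounds with values here, the only measured step, a number 31 percentage points higher from compound 1 to compound 2 (beyond the scatter), shows what the nitro contributes; compound 3 loses it, and no measurement tells what the furan adds. Compound 3 is therefore expected to fall back toward compound 1, a step of a number 26 percentage points lower from compound 2 to compound 3 (beyond the scatter), with an estimated activity of 45%, from 25% to 68%.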

Compound 3, a percentage reported as activity, at one concentration (the size of the read-out at that concentration, not a potency): 45%
For compound 3 middle estimate and measured number coincide at the digits printed; measured number inside the range.
By their numbers in this assay, from the lowest: compounds 1 and 3 (each within the scatter of the next); then compound 2.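

In this assay, 3-methylfuran-2-yl on the saturated ring carbon does not keep what 3-nitrophenyl gave there, with a number 26 percentage points lower from compound 2 to compound 3 (beyond the scatter). Set against phenyl at the same carbon, it gives a number 5 percentage points higher from compound 1 to compound 3 (within the scatter), so of these three groups only 3-nitrophenyl stands apart. No evidence on the cause of this is at hand. Open, from the compounds shown here alone, is whether an amine or a carboxylic acid in place of the nitro would match compound 2, and whether a furan without its methyl would match compound 3.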